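The source may hold more compounds than are shown below. What is called first, only, known or untested is meant among the compounds shown, and "the series" means these compounds.

Compound 2 `O=c1cc(-c2ccc(OCc3ccccc3)cc2)oc2cc(OCCCCCCCCN3CCCC3)ccc12` stands lowest of the three numbers in an ADME assay on HepG2 cells (Homo sapiens) for cytotoxicity, read by MTT assay, with a stated time of 48 h, tested at 1 uM (a lower number here means a weaker effect, a higher number a stronger effect of the compound at the concentration tested), where compound 2 gives 10.4%. Its nearest neighbour is compound 3 `O=c1cc(-c2ccccc2)oc2cc(OCCCCCCCCN3CCCC3)ccc12`, which in this assay gives 11.3%, the step being a number 0.9 percentage points higher from compound 2 to compound 3 (within the scatter). Furthest is compound 1 `O=c1cc(-c2cccc(O)c2)oc2cc(OCCCCCCCCN3CCCC3)ccc12`, which in this assay gives 19%; the two values of compound 1 and compound 2 sit within the scatter of each other. The step of a number 7.7 percentage points lower from compound 1 to compound 3 (within the scatter) likewise stays within the scatter.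

Compound 4 `O=c1cc(-c2ccc(-c3ccccc3)cc2)oc2cc(OCCCCCCCCN3CCCC3)ccc12` differs from compound 2 by phenyl in place of benzyloxy on an aromatic carbon. For the measured compounds named here, the steps that bear on this change are the two on the pendant ring, a number 0.9 percentage points higher from compound 2 to compound 3 (within the scatter) and a number 7.7 percentage points lower from compound 1 to compound 3 (within the scatter), both within the scatter, so no step beyond the scatter in this assay is expected from compound 2 to compound 4. The estimated step is a number 1.6 percentage points higher from compound 2 to compound 4 (within the scatter). Compound 4 is therefore expected to give 12% in this assay, with a range from 3% to 22%.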

Compound 4, a percentage reported as inhibition, at one concentration (the size of the read-out at that concentration, not a potency): 13.9%
Compound 4: the middle estimate sits 1.9 percentage points below what was measured, and the stated range covers the measured number.
By their numbers in this assay, from the lowest: compounds 2, 3, 4 and 1 (each within the scatter of the next).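

In this assay the exchange of benzyloxy for phenyl gives a number 3.5 percentage points higher from compound 2 to compound 4 (within the scatter) and phenyl in place of hydrogen gives a number 2.6 percentage points higher from compound 3 to compound 4 (within the scatter) so this place, para to a large group, now holds hydrogen, benzyloxy and phenyl without any step that leaves the scatter. The change from the 3-hydroxyphenyl of the earlier compound to 4-phenylphenyl gives a number 5.1 percentage points lower from compound 1 to compound 4 (within the scatter) and so adds a whole-ring exchange that also cannot be told apart from no change in this read-out. No evidence is at hand that would explain these results.

As far as these compounds go, whether an amine or a carboxylic acid on the pendant ring would move the read-out beyond the scatter remains open. So does the effect of a longer chain on the shared core in place of the one these compounds carry.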